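Swapping the aryl group on the hydrazone: compound 4

The compounds below may be only part of what the source reports. "The series", "measured", "known", "first", "only" and "open" are said of these compounds alone.

Compound 1 `Cc1ccc(/C=N\NC(=O)C2=C(Cl)c3ccccc3CCC2)cc1`: 260 nM
Compound 2 `COc1cccc(/C=N\NC(=O)C2=C(Cl)c3ccccc3CCC2)c1`: 300 nM
Compound 3 `COc1cc(/C=N\NC(=O)C2=C(Cl)c3ccccc3CCC2)cc(OC)c1OC`: < 10 nM

In a functional assay on MDA-MB-231 cells (Homo sapiens) for inhibition, read by sulforhodamine B assay, with a stated time of 48 h (a higher number here means a weaker inhibitor of growth, a lower number a stronger inhibitor of growth), compound 1 gives 260 nM and compound 2 gives 300 nM. For compound 3 the assay reports only a limit, < 10 nM, not a number; compound 3 sits at the limit of < 10 nM in this assay, at which 1 of the 3 values shown sits. Among the compounds with values here, compound 2 thus holds one of only two real numbers, and the other, from compound 1, lies within the scatter of it, as a 1.2-fold higher number from compound 1 to compound 2 (0.06 log units; within the scatter) shows. Compound 4 `O=C(N/N=C\c1ccc(F)cc1)C1=C(Cl)c2ccccc2CCC1` differs from compound 2 in one place: 4-fluorophenyl in place of 3-methoxyphenyl on a carbon with a double bond to nitrogen. Within the data shown here, the only measured step touching this position is that same exchange of one aryl group for another, which stayed within the scatter. A step of no more than the scatter is therefore expected here as well, no change at the digits printed from compound 2 to compound 4 (within the scatter). Compound 4 is estimated to give 300 nM, expected between 120 nM and 750 nM.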

Compound 4, concentration for 50% growth inhibition: 410 nM
Beside the measured number, compound 4's estimate is 1.4-fold (0.14 log units) below it; the range from low to high includes it.
By their numbers in this assay, from the lowest: compounds 1, 2 and 4 (each within the scatter of the next). At a limit, below all of these: compound 3.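

There is a 1.4-fold higher number from compound 2 to compound 4 (0.14 log units; within the scatter) even though the entering 4-fluorophenyl has no hydrogen-bond acceptor and the leaving 3-methoxyphenyl has one, so that acceptor is not needed to hold this level. Fluoro in place of methyl on an aromatic carbon gives a 1.6-fold higher number from compound 1 to compound 4 (0.20 log units; within the scatter) as well, so a third aryl group joins the same narrow band. No measurement shown explains why these groups read so alike.

Going by these compounds, compound 3 gives < 10 nM, which is a limit of the assay and not a number, so its distance from the others stays open. Also open, on these data alone, is how an aryl group carrying an amine or a carboxylic acid would read at this position.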